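The compounds below may be only part of what the source reports. "The series", "measured", "known", "first", "only" and "open" are said of these compounds alone.

Measured compounds in a functional assay on SW480 cells (Homo sapiens) for cytotoxicity, read by MTT assay, with a stated time of 24 h; a higher number here means a weaker inhibitor, a lower number a stronger inhibitor:
Compound 1 `C=CC1=C(C(=O)NCCC)C(c2ccc(OC)c(OC)c2)OC1` gives > 100000 nM, a limit of the assay.
Compound 2 `C=CC1=C(C(=O)Nc2ccc(OCC)cc2)C(c2ccc(F)cc2)OC1` gives > 100000 nM, likewise a limit.
Compound 3 `C=CC1=C(C(=O)NCCC)C(c2ccc(OC)cc2)OC1` gives > 100000 nM, again a limit.

Compound 1 therefore stands only at a limit; no number is known for it. All three values shown sit at the limit of > 100000 nM in this assay, at which 3 of the 3 values shown sit. For the measured compounds named here, the single step between measured compounds, a step that the two limits leave unreadable from compound 1 to compound 3, runs from one limit to another and its size cannot be read.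

Compound 4 `C=CC1=C(C(=O)NC2CCCCC2)C(c2ccc(OC)c(OC)c2)OC1` differs from compound 1 by cyclohexyl in place of propyl on an amide-type nitrogen. Going by the values given here, no measured step touches the amide-type nitrogen, so neither size nor direction of this change can be drawn from the numbers. Among the compounds with values here, because every value so far rests at the limit of > 100000 nM in this assay, at which 3 of the 3 values shown sit, compound 4 is expected to stay near that limit, the expected step being a step that the limit leaves unreadable from compound 1 to compound 4. In this assay compound 4 is estimated at 150000 nM, ranging from 50000 nM to 500000 nM, most likely again reported only as a limit.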

Compound 4, half-maximal inhibitory concentration: 19100 nM
Compound 4: middle estimate off by 7.9-fold (0.90 log units), on the high side, and the stated range ends above it.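

For the compounds shown here, the amide-type nitrogen is the first position to give a readable change in this assay: an at least 5.2-fold lower number from compound 1 to compound 4 (0.71 log units; beyond the scatter). Compound 1 stands at a limit, > 100000 nM. With cyclohexyl in place of propyl, compound 4 is the only compound shown that comes off the limit: the limit of > 100000 nM in this assay, at which 3 of the 4 values shown sit.

Going by these compounds, whether the ring itself or the added carbon counts stays open; a hexyl chain or a cyclopentyl group on the same nitrogen would separate the two. Going by these compounds alone, also open is whether hydrogen in place of methoxy on an aromatic carbon reads differently with cyclohexyl present, that step so far being unreadable.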